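The source may hold more compounds than are shown below. What is called first, only, known or untested is meant among the compounds shown, and "the series" means these compounds.

Working notes on the series. Compound 1 `CCCNc1nc(C#Cc2ccc(F)s2)nc2c1ncn2[C@H]1[C@H](O)[C@H](O)[C@]2(C(=O)NC)C[C@H]12` carries a propylamino group on the shared core; in an assay on CHO cells for displacement of a labelled ligand from adenosine receptor A3 (Homo sapiens) (on this read-out higher numbers stand for weaker inhibition and lower numbers for stronger inhibition), compound 1 gives 1.13 nM. Compound 2 `CCNc1cc(C#Cc2ccc(F)s2)nc2c1ncn2[C@H]1[C@H](O)[C@H](O)[C@]2(C(=O)NC)C[C@H]12` differs from compound 1 both in the core and in carrying an ethylamino group; in this assay compound 2 gives 2.78 nM. Of the two numbers recorded, compound 1 has the lower one, and the gap to compound 2 is beyond the scatter, so compound 1 stands as the stronger inhibitor of the pair.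

Compound 3 `CNC(=O)[C@@]12C[C@@H]1[C@@H](n1cnc3c(NC)nc(C#Cc4ccc(F)s4)nc31)[C@H](O)[C@@H]2O` is the next member to be measured. Relative to compound 1 the change is hydrogen in place of ethyl on a saturated chain carbon bound to a nitrogen on an aromatic ring. Among the compounds with values here, no measured pair isolates this change, so the size of the step in this assay is unknown. The step of a 1.1-fold lower number from compound 1 to compound 3 (0.05 log units; within the scatter) is expected to be small, with no clear direction beyond the scatter. Compound 3 is accordingly expected to give 1 nM, estimated within a range from 0.3 nM to 3.5 nM.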

Compound 3, inhibition constant: 0.28 nM
For compound 3 the middle estimate is 3.6-fold (0.55 log units) above the measured one; measured number below the stated range.
By their numbers in this assay, from the lowest: compound 3; then compound 1; then compound 2.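

The change from propylamino to methylamino on the shared core now has a measured size in this assay: a 4.0-fold lower number from compound 1 to compound 3 (0.61 log units; beyond the scatter), a modest step. At this place, on a saturated chain carbon bound to a nitrogen on an aromatic ring, hydrogen in place of ethyl therefore lowers the number, and the propyl chain is not required for a low-nanomolar reading in this pair. No measured data on the series offer an explanation for this step.

Going by these compounds, whether an unsubstituted amino group or a butylamino group would continue the same direction remains open, since one step fixes no trend along the chain. Also open, on these data alone, is whether the step carries over to the core of compound 2, which differs from compound 1 in more than one place and so cannot be compared with it.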